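Adding a Methyl Group to a Weaker Cinnamide Analogue

The source may hold more compounds than are shown below. What is called first, only, known or untested is meant among the compounds shown, and "the series" means these compounds.

Of the compounds shown here, two have been measured in a functional assay on A549 cells (Homo sapiens) for antiproliferative activity, read by MTT assay, with a stated time of 48 h; on this read-out lower numbers stand for stronger inhibition and higher numbers for weaker inhibition. Compound 1 `COc1ccc(/C=C/C(=O)Nc2nnc(-c3ccc(C)cc3)s2)cc1` gives 0.66 ug/mL, while compound 2 `O=C(/C=C/c1ccccc1)Nc1nnc(-c2ccccc2)s1` gives 1.75 ug/mL, the higher of the two numbers and therefore the weaker inhibitor here, with a gap to compound 1 that lies beyond the usual scatter. Compound 3 `Cc1ccc(-c2nnc(NC(=O)/C=C/c3ccccc3)s2)cc1` differs from compound 2 in a single spot: methyl in place of hydrogen on an aromatic carbon. For the measured compounds named here, compound 1 carries this same methyl group yet also differs elsewhere, so no clean step isolates its effect. A modest step toward stronger inhibition is expected, a 1.6-fold lower number from compound 2 to compound 3 (0.20 log units; within the scatter), giving an estimated 1.1 ug/mL for compound 3, between 0.5 ug/mL and 2.5 ug/mL.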

Compound 3, half-maximal inhibitory concentration: 1.38 ug/mL
Compound 3: middle estimate off by 1.3-fold (0.10 log units), on the low side; the measured number falls inside the stated range.
By their numbers in this assay, from the lowest: compound 1; then compounds 3 and 2 (each within the scatter of the next).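

Methyl in place of hydrogen, the change from phenyl to 4-methylphenyl, gives a 1.3-fold lower number from compound 2 to compound 3 (0.10 log units; within the scatter) in this assay, so at this position para to a large group the methyl alone does not separate the two compounds. Hydrogen in place of methoxy on an aromatic carbon gives a 2.1-fold higher number from compound 1 to compound 3 (0.32 log units; beyond the scatter), the first single-place step here that clears the scatter. Nothing available explains either step. Still open, going by these compounds, is whether an ethyl, a chlorine or an amine at the methyl position would shift the number further, and whether methoxy would have the same effect on compound 2.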